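Compound 3 to compound 4: adding one methoxy

A few compounds are considered here, and "the series" means these few. Any claim that something is new, unique, unknown or untested is made for them only; others in the source may bear on it.

Measured in an ADME assay on HepG2 2.2.15 cells (Homo sapiens) for cytotoxicity; a higher number here means that more compound is tolerated, a lower number that less compound is tolerated:
- compound 1 `CCC(=O)OCCc1c(-c2ccccc2Cl)c2cc(Cl)ccc2[nH]c1=O` gives 95000 nM
- compound 2 `O=C(OCCc1c(-c2ccccc2Cl)c2cc(Cl)ccc2[nH]c1=O)C1CCCC1` gives 46000 nM
- compound 3 `O=C(/C=C/c1ccccc1)OCCc1c(-c2ccccc2Cl)c2cc(Cl)ccc2[nH]c1=O` gives 230000 nM

Compound 3 has the highest number of the three. The step of a 2.4-fold higher number from compound 1 to compound 3 (0.38 log units; beyond the scatter) and the step of a 5.0-fold higher number from compound 2 to compound 3 (0.70 log units; beyond the scatter) both end there.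

Compound 4 `COc1cccc(/C=C/C(=O)OCCc2c(-c3ccccc3Cl)c3cc(Cl)ccc3[nH]c2=O)c1` keeps the shared core and differs only in the ester group. The change is methoxy in place of hydrogen on an aromatic carbon and it turns 2-phenylethenyl into 2-(3-methoxyphenyl)ethenyl, with the methoxy meta to a large group.

Only ester replacements bear on this, such as a 2.1-fold lower number from compound 1 to compound 2 (0.31 log units; beyond the scatter) and the two steps above, and all of them are modest. Each exchanges the whole group on the carbonyl carbon. Among the compounds with values here, no measured pair tests a substituent on the aromatic ring, so the evidence is indirect. This edit is smaller than those replacements, so no step beyond the scatter is expected, with a slight drop the likelier direction.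

The expected step is a 1.4-fold lower number from compound 3 to compound 4 (0.13 log units; within the scatter) on this estimate.

For compound 4 the estimated value is 170000 nM in a range from 80000 nM to 350000 nM as expected here.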

Compound 4, half-maximal cytotoxic concentration: > 1300000 nM
Compound 4: a limit, no number; the forecaster's own chance of this, stated with the estimate: 15%; middle value at least 7.6-fold (0.88 log units) away from the limit.
By their numbers in this assay, from the lowest: compound 2; then compound 1; then compound 3. At a limit, above all of these: compound 4.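

In this assay the reading for compound 4 is a limit and not a number: the limit of > 1300000 nM in this assay, at which 1 of the 4 values shown sits. A single methoxy on an aromatic carbon, meta to a large group, gives an at least 5.6-fold higher number from compound 3 to compound 4 (0.75 log units; beyond the scatter), so a substituent at this place on the ring can shift the read-out beyond the scatter, which the exchanges of the whole group on the carbonyl carbon had not tested. Within the data shown here, measured against those other esters, the steps are an at least 28-fold higher number from compound 2 to compound 4 (1.45 log units; beyond the scatter) and an at least 13-fold higher number from compound 1 to compound 4 (1.13 log units; beyond the scatter), the only large steps so far.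

Going by these compounds, since the reading is a limit, the full size of these steps stays open. On these data alone, whether the shift belongs to methoxy itself or to any addition at this place also stays open, and a hydroxyl, a chlorine or a dimethylamino group on the same aromatic carbon would bear on that.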